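Swapping Ethoxy for Trifluoromethyl in Compound 3

The source may hold more compounds than are shown below. What is called first, only, known or untested is meant among the compounds shown, and "the series" means these compounds.

Within the data shown here, compound 2 `CCOc1ccc(-c2nc(C(F)(F)F)sc2N2CCN(C(=O)Cn3nc(C)nc3C)[C@H](C)C2)cn1` is one of two compounds measured in a functional assay on CHO-K1 cells for antagonist activity at C-X-C chemokine receptor type 3 (Homo sapiens), read by FLIPR, with a stated time of 10 min (a higher number here means a weaker inhibitor, a lower number a stronger inhibitor), where compound 2 gives 8.8 nM. Compound 1 `CCc1ncc(-c2nc(C(F)(F)F)sc2N2CCN(C(=O)Cn3nc(C)nc3C)[C@H](C)C2)cn1`, which differs from it only by 2-ethylpyrimidin-5-yl in place of 6-ethoxypyridin-3-yl on an aromatic carbon, gives 14 nM in this assay . The step of a 1.6-fold lower number from compound 1 to compound 2 (0.20 log units; within the scatter) lies within the scatter, so compound 2 merely carries the lower of the two numbers and is not separated from compound 1 in any meaningful way. The unmeasured compound 3 `Cc1nc(C)n(CC(=O)N2CCN(c3sc(C(F)(F)F)nc3-c3ccc(C(F)(F)F)nc3)C[C@H]2C)n1` differs from compound 2 by trifluoromethyl in place of ethoxy on an aromatic carbon. Among the measured compounds shown here, no measured step bears directly on that position: the single step on record exchanged the whole aryl ring and produced nothing beyond the scatter. For the measured compounds named here, with that as the only guidance, no movement beyond the scatter is expected in this assay , and the expected step is a 1.1-fold higher number from compound 2 to compound 3 (0.06 log units; within the scatter), stated with a broad range. Compound 3 is therefore estimated at 10 nM in this assay , between 3 nM and 35 nM.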

Compound 3, half-maximal inhibitory concentration: 4.2 nM
Compound 3: middle estimate off by 2.4-fold (0.38 log units), on the high side; measured number inside the range.
By their numbers in this assay, from the lowest: compound 3; then compounds 2 and 1 (each within the scatter of the next).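

Among these compounds, with trifluoromethyl in place of ethoxy, this assay records a 2.1-fold lower number from compound 2 to compound 3 (0.32 log units; beyond the scatter), the first change on record that moves the number beyond the scatter. The exchange concerns only the group on the six-membered aromatic ring with 1 nitrogen, next to the ring nitrogen, so this place responds to a change of a single group, which the earlier exchange of the whole aryl ring, a 1.6-fold lower number from compound 1 to compound 2 (0.20 log units; within the scatter), did not show. Compound 3 is also set apart from the pyrimidine-bearing compound by a 3.3-fold lower number from compound 1 to compound 3 (0.52 log units; beyond the scatter), a modest step beyond the scatter, and nothing shown explains either step.

From the compounds shown here alone, these compounds rest the finding at this place on one pair, so it stays open whether a smaller group such as methoxy, chloro or nitrile, a longer chain such as propoxy, or an amine would give a number nearer compound 3 or compound 2. Going by these compounds, it also stays open whether trifluoromethyl would give a similar step on the pyrimidine ring of compound 1, in place of the ethyl group there.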